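The compounds below may be only part of what the source reports. "The series", "measured", "known", "first", "only" and "open" are said of these compounds alone.

Working notes on a small set of analogues tested in a functional assay on Hs 683 cells (Homo sapiens) for inhibition, read by colorimetric assay and MTT assay, with a stated time of 72 h; on this read-out lower numbers stand for stronger inhibition and higher numbers for weaker inhibition. Compound 1 `COc1ccc(C(=O)NNC(=S)Nc2csc(-c3ccccc3)c2)cc1` gives 35000 nM in this assay. Compound 2 `O=C(NNC(=S)Nc1csc(-c2ccccc2)c1)c1ccc(O)cc1` differs from compound 1 by hydrogen in place of methyl on an oxygen on an aromatic ring and in this assay compound 2 gives 80000 nM; the step is a 2.3-fold higher number from compound 1 to compound 2 (0.36 log units; beyond the scatter). Compound 3 `COc1ccc(-c2nnc(Nc3csc(-c4ccccc4)c3)s2)cc1` carries a different core, and the difference between the two cores is not broken down here. In this assay compound 3 gives 5000 nM, the lowest number of the three measured, with compound 1 the nearest and compound 2 the furthest.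

Compound 4 `Oc1ccc(-c2nnc(Nc3csc(-c4ccccc4)c3)s2)cc1` has not been measured. It stands to compound 3 as compound 2 stands to compound 1: the change is hydrogen in place of methyl on an oxygen on an aromatic ring, and the place is the same word for word in both pairs, so it is the same change set on the other core. For the measured compounds named here, the only guide to its size is the single measured occurrence, which raised the number beyond the scatter but only modestly. Assuming the change carries over, the expected step in this assay is a 2.2-fold higher number from compound 3 to compound 4 (0.34 log units; beyond the scatter), to be set beside the measured 2.3-fold higher number from compound 1 to compound 2 (0.36 log units; beyond the scatter). The estimate for compound 4 in this assay is therefore 11000 nM, expected to fall between 4000 nM and 30000 nM; the range is kept wide because the lone step a 2.3-fold higher number from compound 1 to compound 2 (0.36 log units; beyond the scatter) is all that backs the transfer to a different core.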

Compound 4, half-maximal inhibitory concentration: 26000 nM
Estimate against measurement, compound 4: 2.4-fold (0.37 log units) below; the measured number falls inside the stated range.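

In this assay, the change from methoxy to hydroxy on the second core gives a 5.2-fold higher number from compound 3 to compound 4 (0.72 log units; beyond the scatter), so the number goes up on both cores. Set beside the earlier step, the two sizes cannot be told apart: the same change on two cores in this assay, a 2.3-fold higher number (0.36 log units; beyond the scatter) from compound 1 to compound 2 and a 5.2-fold higher number (0.72 log units; beyond the scatter) from compound 3 to compound 4, 2.3-fold (0.36 log units) apart, within the scatter of two such steps. This shows that the direction of the change, and its size within the scatter, carried over between these two cores, but two occurrences do not show that it would hold on any further core, and they do not say what lies behind the rise.

The compounds shown leave open how an amine, a carboxylic acid or a longer chain such as ethoxy would compare with methoxy and hydroxy on that aromatic ring, on either core. Also open, going by these compounds, is what a change on the phenyl group common to all four compounds would do, and whether the step from 4-methoxyphenyl to 4-hydroxyphenyl keeps its direction on a core other than these two.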